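A few compounds are considered here, and "the series" means these few. Any claim that something is new, unique, unknown or untested is made for them only; others in the source may bear on it.

Series read in an ADME assay (liver) for metabolic stability, with Liver microsome (Rattus norvegicus) as the target, read by LC-MS, using microsomes and NADPH, with stated times of 5 min and 60 min, tested at 4 uM; on this read-out higher numbers stand for a more stable compound and lower numbers for a less stable compound:

- compound 1 `Cc1c(OCCCCOc2ccc(C(=O)O)cc2Cl)ccc(C(=O)CC2CCCC2)c1O`: 21%
- compound 2 `Cc1c(OCCCCOc2cccc(C(=O)O)c2)ccc(C(=O)CC2CCCC2)c1O`: 55%
- compound 3 `Cc1ccc(C(=O)O)cc1OCCCCOc1ccc(C(=O)CC2CCCC2)c(O)c1C`: 9%

Compound 3 stands lowest of the three at 9%, below the other two by steps beyond the scatter. Compound 4 `Cc1cc(C(=O)O)ccc1OCCCCOc1ccc(C(=O)CC2CCCC2)c(O)c1C` has 4-carboxy-2-methylphenyl in place of 5-carboxy-2-methylphenyl on an oxygen on a saturated carbon. Within the data shown here, no measured step isolates this change. The closest evidence is the modest step of a number 12 percentage points lower from compound 1 to compound 3 (beyond the scatter), which also replaces the 4-carboxy-2-chlorophenyl group that resembles the entering group. The large step of a number 46 percentage points lower from compound 2 to compound 3 (beyond the scatter) and the large step of a number 34 percentage points higher from compound 1 to compound 2 (beyond the scatter) show how strongly this assay responds to changes in this ring, so the uncertainty is wide. Compound 4 keeps the methyl that compound 2 lacks, and a return towards 55% is not expected. The expected step is small and upward, a number 8 percentage points higher from compound 3 to compound 4 (within the scatter), which is not expected to be a clear change beyond the scatter. For compound 4 the estimated value is 17%, with an expected range of 6% to 35%.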

Compound 4, percent of the compound remaining: 59%
Compound 4: middle estimate off by 42 percentage points, on the low side; measured number above the stated range.
By their numbers in this assay, from the lowest: compound 3; then compound 1; then compounds 2 and 4 (each within the scatter of the next).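

In this assay, a change of arrangement alone, with the same atoms, carries a large step: 4-carboxy-2-methylphenyl in place of 5-carboxy-2-methylphenyl on the oxygen gives a number 50 percentage points higher from compound 3 to compound 4 (beyond the scatter). The methyl therefore does not go with a low number in every arrangement, since the comparison with the 3-carboxyphenyl group reads a number 4 percentage points higher from compound 2 to compound 4 (within the scatter) and shows no clear difference. With the carboxy arrangement held, the other ring substituent also matters, as methyl in place of chloro gives a number 38 percentage points higher from compound 1 to compound 4 (beyond the scatter).

Open, as far as these compounds go, is how a methoxy group in place of that methyl, or an unsubstituted 4-carboxyphenyl ring, would read, and whether a longer chain to the oxygen would keep these differences. Nothing at hand bears on the reason for these steps.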